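Lengthening the amine chain: from allyl to butyl

The source may report more compounds than this note shows. Statements on the series, on what has been measured and on what is new or still open speak of the compounds shown alone.

Compound 2 `C=CCNC(=C\C(=O)/C=C/c1ccc(O)c(OC)c1)/C=C/c1ccc(O)c(OC)c1` was tested in a functional assay on EA.hy 926 cells (Homo sapiens), read by fluorescence, tested at 1 uM (a higher number here means a stronger effect of the compound at the concentration tested, a lower number a weaker effect), and gives 124%. Among the three compounds measured, compound 2 stands second highest. Compound 3 `O=C(/C=C(/C=C/c1ccc(O)cc1)NC1CCCCC1)/C=C/c1ccc(O)cc1`, which carries a cyclohexyl group on the amine nitrogen and lacks the methoxy groups, gives 129%, within the scatter of compound 2. Compound 1 `CCCNC(=C\C(=O)/C=C/c1ccc(O)c(OC)c1)/C=C/c1ccc(O)c(OC)c1` gives 78%, well below.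

The unmeasured compound 4 `CCCCNC(=C\C(=O)/C=C/c1ccc(O)c(OC)c1)/C=C/c1ccc(O)c(OC)c1` differs from compound 2 in one place: propyl in place of vinyl on a saturated chain carbon bound to an amine nitrogen

Within the data shown here, one measured step bears on this change: a number 46 percentage points higher from compound 1 to compound 2 (beyond the scatter). That step is the same kind of change run in the opposite direction, so its size suggests that going back from an allyl to a saturated chain on the amine nitrogen costs activity. Among the measured compounds shown here, compound 4 has one more carbon than compound 1, and no measured compound shows what that extra carbon does, so the expected drop is given a wide range.

For compound 4, a step of a number 39 percentage points lower from compound 2 to compound 4 (beyond the scatter) is therefore expected, and compound 4 is estimated at 85%, most likely between 55% and 115%.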

Compound 4, a percentage reported as activity, at one concentration (the size of the read-out at that concentration, not a potency): 110%
For compound 4 the middle estimate is 25 percentage points below the measured one; low and high end bracket the measured number.
By their numbers in this assay, from the lowest: compound 1; then compound 4; then compounds 2 and 3 (each within the scatter of the next).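

Butyl in place of allyl on the amine nitrogen lowers the read-out in this assay only modestly, a number 14 percentage points lower from compound 2 to compound 4 (beyond the scatter), so among these compounds a double bond in the chain is not required for a high number. Chain length also matters among the saturated chains, since one added methyl on a saturated chain carbon, three bonds along the chain from the amine nitrogen, gives a number 32 percentage points higher from compound 1 to compound 4 (beyond the scatter). Nothing available explains why these chains differ.

Going by these compounds, it remains open whether a longer chain, such as hexyl, would continue this rise or reverse it. A branched chain such as isobutyl is also untested in this series, and compound 3 differs in more than one place, so it cannot settle what a ring on the nitrogen does.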